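Swapping a Benzylamino Group for a Basic Amine Chain

The source may hold more compounds than are shown below. What is called first, only, known or untested is meant among the compounds shown, and "the series" means these compounds.

Going by the values given here, compound 2 `Nc1nc(C(F)(F)F)cc2c1[nH]c(=O)n2Cc1ccc(NCc2ccccc2)nc1` gives 16 mL.min-1.g-1 in an in vitro ADME assay on microsomes from liver (Rattus norvegicus) for pharmacokinetics (a lower number here means slower removal, a higher number faster removal of the compound), the only plain number among the values shown. Compound 1 `CN(C)CCN1CCN(c2ccc(Cn3c(=O)[nH]c4c(N)nc(C(F)(F)F)cc43)cn2)CC1` reaches only the assay limit of < 8.5 mL.min-1.g-1 in this assay. Among the compounds with values here, the one measured step is an at least 1.8-fold higher number from compound 1 to compound 2 (0.27 log units; that floor lies within the scatter). Compound 3 `CN(C)CCN(C)c1ccc(Cn2c(=O)[nH]c3c(N)nc(C(F)(F)F)cc32)cn1` differs from compound 2 by (2-(dimethylamino)ethyl)(methyl)amino in place of benzylamino on an aromatic carbon. Compound 1 carries a related amine, and its value sits at the limit (the limit of < 8.5 mL.min-1.g-1 in this assay, at which 1 of the 2 values shown sits). A step back toward slower removal is therefore expected, of about a 2.0-fold lower number from compound 2 to compound 3 (0.30 log units; within the scatter). Compound 3 is estimated at 8 mL.min-1.g-1, between 4 mL.min-1.g-1 and 16 mL.min-1.g-1.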

Compound 3, intrinsic clearance in microsomes: 11 mL.min-1.g-1
For compound 3 the middle estimate is 1.4-fold (0.14 log units) below the measured one, and the stated range covers the measured number.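

In this assay, putting the ringless (2-(dimethylamino)ethyl)(methyl)amino in place of benzylamino next to the ring nitrogen gives a 1.5-fold lower number from compound 2 to compound 3 (0.16 log units; within the scatter), so this change does not clearly separate the two compounds. Replacing 4-(2-(dimethylamino)ethyl)piperazin-1-yl with the same group gives an at least 1.2-fold higher number from compound 1 to compound 3 (0.11 log units; that floor lies within the scatter), which settles nothing either. Compound 1 remains only a limit of the assay: the limit of < 8.5 mL.min-1.g-1 in this assay, at which 1 of the 3 values shown sits.

On these data alone, it remains open whether a morpholine, a carboxylic acid or a longer chain at this position would move the number beyond the scatter.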